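Trimming a Methyl from the Aryl Ring

A few compounds are considered here, and "the series" means these few. Any claim that something is new, unique, unknown or untested is made for them only; others in the source may bear on it.

Of the compounds shown here, three in this set have been measured, and a fourth awaits its number. Compound 1 `COc1cc2c(Oc3ccc(NC(=O)c4nn(-c5ccc(C)cc5C)cc(C)c4=O)cc3)ccnc2cc1OCCCCCCC(=O)NO` gave in a functional assay on MCF7 cells (Homo sapiens) for inhibition, read by MTT assay, with a stated time of 72 h (a lower number here means a stronger inhibitor, a higher number a weaker inhibitor), a value of 2430 nM. Compound 2 `COc1cc2c(Oc3ccc(NC(=O)c4nn(-c5ccc(C)cc5)cc(C)c4=O)cc3)ccnc2cc1OCCCCCCC(=O)NO` differs from it by hydrogen in place of methyl on an aromatic carbon, and in this assay compound 2 gave 2560 nM, so the step is a 1.1-fold higher number from compound 1 to compound 2 (0.02 log units; within the scatter). Compound 3 `COc1cc2c(Oc3ccc(NC(=O)c4nn(-c5ccccc5C)cc(C)c4=O)cc3F)ccnc2cc1OCCCC(=O)NO` gave 2600 nM in this assay; the difference between the core of compound 3 and the core of compound 1 is not broken down here, and the two values lie within the scatter of each other.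

Compound 4 `COc1cc2c(Oc3ccc(NC(=O)c4nn(-c5ccccc5)cc(C)c4=O)cc3F)ccnc2cc1OCCCC(=O)NO` has not yet been measured in this assay. It differs from compound 3 by hydrogen in place of methyl on an aromatic carbon. Going by the values given here, this is the same kind of change as the one from compound 1 to compound 2, though not the same: in compound 1 the methyl that leaves sits ortho to a large group and meta to a methyl group (1 heavy atom), whereas in compound 3 the methyl that leaves sits ortho to a large group only, with no second methyl on that ring.

Since the earlier step of a 1.1-fold higher number from compound 1 to compound 2 (0.02 log units; within the scatter) stayed within the scatter, compound 4 is expected to stand close to compound 3, with an estimated step of a 1.0-fold higher number from compound 3 to compound 4 (0.02 log units; within the scatter). Compound 4 is therefore estimated at 2700 nM in this assay, with an expected range from 1300 nM to 5600 nM.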

Compound 4, half-maximal inhibitory concentration: 1900 nM
Beside the measured number, compound 4's estimate is 1.4-fold (0.15 log units) above it, within the range that was stated.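

In this assay, going from 2-methylphenyl to phenyl gives a 1.4-fold lower number from compound 3 to compound 4 (0.14 log units; within the scatter). Set beside the earlier case of hydrogen in place of methyl on an aromatic carbon, the new step does not stand apart from it: the same change on two cores in this assay, a 1.1-fold higher number (0.02 log units; within the scatter) from compound 1 to compound 2 and a 1.4-fold lower number (0.14 log units; within the scatter) from compound 3 to compound 4, 1.4-fold (0.16 log units) apart, within the scatter of two such steps. On these two cores, then, the change left the number within the scatter both times, and nothing separates its outcome on one core from its outcome on the other, but two pairs cannot show that the change is without effect throughout the series or that every core would respond alike, and in compound 1 a second methyl remains on the ring, which is not so in compound 3.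

The compounds shown leave open what a methoxy group, a chlorine atom or an amine on that same aromatic carbon would do to the number in this assay. Going by these compounds alone, they also leave open whether the fluorine or the chain length, both of which differ between the two cores, has any bearing on the step, as no pair here varies either of them alone.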